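This account rests on a few compounds, and the source may have more. Where it says the series, first, only, none or still open, it means among the compounds named here.

Compound 1 `CCS(=O)(=O)Nc1cc(C2CCCCC2)cc2c1CCCC2c1c[nH]cn1` and compound 2 `CCS(=O)(=O)Nc1cccc(-c2c[nH]cn2)c1` share an ethylsulfonamide on a benzene ring, but compound 1 carries a much larger framework around it. In an assay on isolated protein for binding affinity to Alpha-1A adrenergic receptor (Rattus norvegicus), read by radioligand binding (a higher number here means a weaker inhibitor, a lower number a stronger inhibitor), compound 1 gives 269 nM. Compound 2 stands at the edge of what the measurement can report: its value, < 10000 nM, is a limit of this assay and not a number, as the limit of < 10000 nM in this assay, at which 1 of the 2 values shown sits, notes. Among the compounds with values here, it can be said only that compound 2 is a weak binder on this evidence, with no firm figure to compare against compound 1.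

Compound 3 `CCS(=O)(=O)Nc1cccc(NC2=NCCN2)c1` is not yet measured. It differs from compound 2 in one place: a group of 6 heavy atoms (3 carbon, 3 nitrogen; one five-membered non-aromatic ring with 2 hetero atoms) in place of a group of 5 heavy atoms (3 carbon, 2 nitrogen; one five-membered aromatic ring with 2 hetero atoms), on an aromatic carbon. Within the data shown here, no measured pair shows this change, so the expected step that the limit leaves unreadable from compound 2 to compound 3 is a guess toward somewhat stronger binding. Compound 3 is expected to give about 3000 nM, within 400 nM to 20000 nM.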

Compound 3, inhibition constant: 2950 nM
The estimate for compound 3 lay 1.0-fold (0.01 log units) above the measured number; low and high end bracket the measured number.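

Compound 2 has only a limit and not a number, so no size can be read for the change from compound 2 to compound 3: the limit of < 10000 nM in this assay, at which 1 of the 3 values shown sits.

The compounds shown leave open how much, or even whether, replacing the 1H-imidazol-4-yl group with the five-membered non-aromatic ring changes binding in this assay.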